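Methylsulfanyl in Place of Trifluoromethyl: an Expected Cytotoxicity

The source may report more compounds than this note shows. Statements on the series, on what has been measured and on what is new or still open speak of the compounds shown alone.

Compound 1 `O=C(/C=C/c1ccc2c(c1)B(O)OC2)c1ccc(C(F)(F)F)cc1` has been tested in an ADME assay on L929 cells (Mus musculus) for cytotoxicity, read by resazurin assay, with a stated time of 72 h; on this read-out higher numbers stand for weaker inhibition and lower numbers for stronger inhibition. In this assay compound 1 gives only a limit, > 10 ug/mL, so no exact number is known for it, and it stands at the limit of > 10 ug/mL in this assay, at which 1 of the 2 values shown sits. Compound 2 `COc1ccc(C(=O)/C=C/c2ccc3c(c2)B(O)OC3)c(OC)c1` gives 7.87 ug/mL in this assay. Compound 3 `CSc1ccc(C(=O)/C=C/c2ccc3c(c2)B(O)OC3)cc1` has not yet been measured. It differs from compound 1 by methylsulfanyl in place of trifluoromethyl on an aromatic carbon. Within the data shown here, no measured pair shows what this change does, so the step of a number no higher from compound 1 to compound 3 (the limit leaves the size open) is expected to stay within the usual scatter, with no clear direction. Compound 3 is therefore expected to give about 10 ug/mL, most likely between 5 ug/mL and 20 ug/mL.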

Compound 3, half-maximal inhibitory concentration: > 10 ug/mL
Compound 3: only a limit was reported; the forecaster's own chance of this, stated with the estimate: 50%; the middle value lies on the limit itself.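

Compound 1 and compound 3 are each reported only as a limit, so no step can be read between them: the limit of > 10 ug/mL in this assay, at which 2 of the 3 values shown sit.

On these data alone, whether methylsulfanyl in place of trifluoromethyl shifts cytotoxicity at all, and in which direction, stays open.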